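A few compounds are considered here, and "the series" means these few. Any claim that something is new, unique, unknown or untested is made for them only; others in the source may bear on it.

Measured compounds in a functional assay on A549 cells (Homo sapiens) for inhibition, read by sulforhodamine B assay; on this read-out higher numbers stand for weaker inhibition and lower numbers for stronger inhibition:
- compound 1 `COC(=O)CC/C(C)=C/Cc1c(OC)c(C)c2c(c1OCC#CCN1CCCc3ccccc31)C(=O)OC2`: 18000 nM
- compound 2 `COC(=O)CC/C(C)=C/Cc1c(OC)c(C)c2c(c1OCC#CCN1CCC(C(=O)OC)CC1)C(=O)OC2`: 40500 nM
- compound 3 `COC(=O)CC/C(C)=C/Cc1c(OC)c(C)c2c(c1OCC#CCN1CCN(C(=O)C3COc4ccccc4O3)CC1)C(=O)OC2`: > 50000 nM, a limit of the assay and not a number

Compound 2 holds the highest of the two numbers given; compound 1 sits at the nearest number, and the change from 1,2,3,4-tetrahydroquinolin-1-yl to 4-(methoxycarbonyl)piperidin-1-yl gave a 2.3-fold higher number from compound 1 to compound 2 (0.35 log units; beyond the scatter). Compound 3 reaches only (the limit of > 50000 nM in this assay, at which 1 of the 3 values shown sits), so it adds no number to compare.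

Compound 4 `COC(=O)CC/C(C)=C/Cc1c(OC)c(C)c2c(c1OCC#CCN1CCC(Cc3ccccc3)CC1)C(=O)OC2` differs from compound 2 in one place: benzyl in place of methoxycarbonyl on a saturated ring carbon. Among the measured compounds shown here, the only measured step that bears on it is the one from compound 1 to compound 2, which was modest and ran toward a higher number when an aromatic ring was lost and methoxycarbonyl arrived. Compound 4 brings a benzyl, so the expected step in this assay is estimated as a 1.6-fold lower number from compound 2 to compound 4 (0.21 log units; within the scatter), roughly undoing the measured step within a wide band. Compound 4 is therefore estimated at 25000 nM, between 10000 nM and 50000 nM.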

Compound 4, half-maximal inhibitory concentration: 40700 nM
Compound 4: middle estimate off by 1.6-fold (0.21 log units), on the low side, within the range that was stated.
By their numbers in this assay, from the lowest: compound 1; then compounds 2 and 4 (each within the scatter of the next). At a limit, above all of these: compound 3.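

In this assay, the exchange on this saturated ring carbon, three ring bonds from the ring nitrogen, gave a 1.0-fold higher number from compound 2 to compound 4 (0.00 log units; within the scatter), so this assay does not separate benzyl from methoxycarbonyl at this position. The earlier step changed the whole group on the chain and left open whether a six-membered aromatic ring of carbon only went with a lower number; a ring of that kind entering here leaves compound 2 and compound 4 within the scatter of each other. Compound 3 remains a limit of the assay and not a number: the limit of > 50000 nM in this assay, at which 1 of the 4 values shown sits.

From the compounds shown here alone, whether an amine or a carboxylic acid on this ring carbon would read differently stays open. So does whether a longer chain in place of the benzyl would separate from compound 4.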